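Hydroxyphenyl isomer swap at the position opposite the nitrogen

This account rests on a few compounds, and the source may have more. Where it says the series, first, only, none or still open, it means among the compounds named here.

Compound 2 `Oc1cccc(-c2cc(-c3ccccc3O)nc(-c3ccccc3O)c2)c1` gives 5020 nM in a functional assay on HCT-15 cells (Homo sapiens) for cytotoxicity, read by CCK-8 assay, with a stated time of 4 days (on this read-out lower numbers stand for stronger inhibition and higher numbers for weaker inhibition), the lowest of the two numbers in hand, with compound 1 `Oc1ccc(-c2cc(-c3ccc(O)cc3)nc(-c3ccc(O)cc3)c2)cc1` nearest at 5120 nM in this assay, within the scatter of compound 2. Compound 3 `Oc1cccc(-c2cc(-c3cccc(O)c3)nc(-c3ccccc3O)c2)c1` reaches only > 50000 nM in this assay, a limit of the assay rather than a number. One of the three values therefore sits at the limit of > 50000 nM in this assay, at which 1 of the 3 values shown sits. Within the data shown here, the single measured step is an at least 9.9-fold higher number from compound 2 to compound 3 (0.99 log units; beyond the scatter), with 3-hydroxyphenyl in place of 2-hydroxyphenyl on an aromatic carbon.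

Compound 4 `Oc1ccccc1-c1cc(-c2ccccc2O)nc(-c2ccccc2O)c1` differs from compound 2 by 2-hydroxyphenyl in place of 3-hydroxyphenyl on an aromatic carbon. This runs in the opposite sense to the measured step, where 2-hydroxyphenyl replaced by 3-hydroxyphenyl was at least modest and beyond the scatter, though here the exchange sits at a different place on the shared core, so a smaller effect is expected. Compound 4 is accordingly estimated at 3000 nM in this assay, within 1000 nM to 9000 nM. That estimate means an expected 1.7-fold lower number from compound 2 to compound 4 (0.22 log units; within the scatter), a modest lowering that may not clear the scatter.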

Compound 4, half-maximal inhibitory concentration: 2180 nM
Compound 4: middle estimate off by 1.4-fold (0.14 log units), on the high side; low and high end bracket the measured number.
By their numbers in this assay, from the lowest: compound 4; then compounds 2 and 1 (each within the scatter of the next). At a limit, above all of these: compound 3.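

In this assay, 2-hydroxyphenyl in place of 3-hydroxyphenyl opposite the ring nitrogen gives a 2.3-fold lower number from compound 2 to compound 4 (0.36 log units; beyond the scatter) and shows that this position responds to the isomer swap alone, although the leaving and entering groups have the same counted atoms. Compound 3, changed at a different place on the shared core, stays at a limit of the assay at > 50000 nM and so gives no size for its exchange, but 2-hydroxyphenyl is on the lower side in both exchanges from compound 2, and no compound shown goes against this. Nothing in hand gives a cause for the new step.

From the compounds shown here alone, still open at this position is a group other than a hydroxyl on the phenyl ring, such as an amine or a carboxylic acid. Also open, going by these compounds, is whether 4-hydroxyphenyl here, with the two 2-hydroxyphenyl groups kept, would fall with compound 4 or with compound 2.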